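Methoxy on the pendant phenyl of a quinoline amide series

The source may hold more compounds than are shown below. What is called first, only, known or untested is meant among the compounds shown, and "the series" means these compounds.

Compound 1 `COc1cc2c(Oc3ccc(NC(=O)c4cc(-c5ccccc5)nc5ccccc45)cc3F)ccnc2cc1OCCCN1CCC(C)CC1` and compound 2 `COc1ccc(-c2cc(C(=O)Nc3ccc(Oc4ccnc5cc(OCCCN6CCC(C)CC6)c(OC)cc45)c(F)c3)c3ccccc3n2)cc1` share one core and differ by methoxy in place of hydrogen on an aromatic carbon. In a functional assay on MKN-45 cells (Homo sapiens) for cytotoxicity, read by MTT assay, with a stated time of 72 h (a higher number here means a weaker inhibitor, a lower number a stronger inhibitor), compound 1 gives 19 nM, while compound 2 gives 320 nM, and the step is a 17-fold higher number from compound 1 to compound 2 (1.23 log units; beyond the scatter). Compound 3 `COc1cc2c(Oc3ccc(NC(=O)c4cc(-c5ccccc5)nc5ccc(F)cc45)cc3F)ccnc2cc1OCCCN1CCCCC1` gives 30 nM in this assay; the difference between the core of compound 3 and the core of compound 1 is not broken down here. Compound 4 `COc1cccc(-c2cc(C(=O)Nc3ccc(Oc4ccnc5cc(OCCCN6CCCCC6)c(OC)cc45)c(F)c3)c3cc(F)ccc3n2)c1` is not yet measured and differs from compound 3 by methoxy in place of hydrogen on an aromatic carbon. This is the same kind of change as that from compound 1 to compound 2, but the place is not the same: para to a large group there, meta to a large group here. Resting on the earlier step of a 17-fold higher number from compound 1 to compound 2 (1.23 log units; beyond the scatter), compound 4 is expected to give a higher number than compound 3, a step of a 5.0-fold higher number from compound 3 to compound 4 (0.70 log units; beyond the scatter), taken as smaller given the differing place. The estimate for compound 4 is 150 nM, expected between 50 nM and 500 nM.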

Compound 4, half-maximal inhibitory concentration: 690 nM
Compound 4: the middle estimate sits 4.6-fold (0.66 log units) below what was measured, and the stated range ends below it.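

Methoxy in place of hydrogen on the pendant phenyl raises the number on the second core as well, with a 23-fold higher number from compound 3 to compound 4 (1.36 log units; beyond the scatter) in this assay, and the two steps do not differ: the same change on two cores in this assay, a 17-fold higher number (1.23 log units; beyond the scatter) from compound 1 to compound 2 and a 23-fold higher number (1.36 log units; beyond the scatter) from compound 3 to compound 4, 1.4-fold (0.14 log units) apart, within the scatter of two such steps

The penalty therefore carries across these two cores, although the methoxy stands meta to a large group in compound 4 and at another place in compound 2. Two pairs in one cell assay do not separate the place of the methoxy from the difference between the cores, and they do not show that the step holds on any other core.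

On these data alone, whether a hydroxyl, a chlorine or an amine on the pendant phenyl gives a step of this size remains open. So does the size of the step on a core with a longer ether chain.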